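Compound 3: replacing the amide-nitrogen methylpyrazine

The source may hold more compounds than are shown below. What is called first, only, known or untested is meant among the compounds shown, and "the series" means these compounds.

In a physicochemical assay for lipophilicity (a higher number here means a more lipophilic compound, a lower number a more polar compound), compound 1 (`COC[C@H](C)Oc1cc(Oc2cnc(C(=O)N3CCC3)cn2)cc(C(=O)Nc2cnc(C)cn2)c1`) gives 2.4 and compound 2 (`COC[C@H](C)Oc1cc(Oc2ccc(C(=O)N3CCC3)nc2)cc(C(=O)Nc2cnc(C)cn2)c1`) gives 2.9 on the same scale. Compound 3 (`Cc1cnc(NC(=O)c2cc(Oc3ccc(C(=O)N4CCC4)cc3)cc(O[C@@H](C)CO)c2)cn1`) gives 2.4 and stands level with compound 1 within the scatter. Those two together hold the lowest number of the three, while compound 2 lies higher than compound 3 by a gap beyond the scatter.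

The next entry is compound 4 (`C[C@@H](CO)Oc1cc(Oc2ccc(C(=O)N3CCC3)cc2)cc(C(=O)Nc2ccn(C)n2)c1`). It carries 1-methyl-1H-pyrazol-3-yl in place of 5-methylpyrazin-2-yl on an amide-type nitrogen. For the measured compounds named here, no measured pair isolates this replacement, so the expectation rests on the structural change alone and remains uncertain. A small downward move, within the scatter, is expected (a number 0.10 log units lower from compound 3 to compound 4 (within the scatter)) and no larger shift is anticipated. In this assay the estimate for compound 4 is 2.3 with an expected range from 1.9 to 2.7 around it.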

Compound 4, distribution coefficient: 1.8
Compound 4: middle estimate off by 0.50 log units, on the high side; measured number below the stated range.
By their numbers in this assay, from the lowest: compound 4; then compounds 1 and 3 (each within the scatter of the next); then compound 2.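

For the compounds shown here, this is the first step that isolates a single place. On an amide-type nitrogen, 1-methyl-1H-pyrazol-3-yl in place of 5-methylpyrazin-2-yl gives, in this assay, a number 0.60 log units lower from compound 3 to compound 4 (beyond the scatter) and sets compound 4 lowest of the four. The step therefore shows that this position can move the number beyond the scatter, even though the computed counts of hydrogen-bond donors and acceptors are the same on both sides and neither group carries a net charge. Going by these compounds alone, nothing measured so far bears on what lies behind the step.

Going by these compounds, whether the same replacement gives a similar step on the core of compound 1 or compound 2 remains open. Also open, on these data alone, is how a 1-ethyl-1H-pyrazol-3-yl group or a pyridin-2-yl group on the same nitrogen would compare.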